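From a hydroxyl to a fluorine on the sulfonyl aryl

A few compounds are considered here, and "the series" means these few. Any claim that something is new, unique, unknown or untested is made for them only; others in the source may bear on it.

Compound 1, `O=S(=O)(Nc1ccc2oc(-c3ccccc3)nc2c1)c1ccccc1O`, is one of three related sulfonamides tested in an assay on isolated protein for inhibition of malate dehydrogenase, mitochondrial (Sus scrofa), with stated times of 45 min and 30 min; on this read-out lower numbers stand for stronger inhibition and higher numbers for weaker inhibition. In this assay compound 1 reaches only the limit of > 63000 nM, which is a boundary of the measurement and not a number. Compound 2, `O=S(=O)(Nc1ccc(-c2nc3ccccc3o2)cc1)c1ccc(C(F)(F)F)cc1`, likewise gives only a limit of > 63000 nM in this assay. Compound 3, `COc1ccccc1S(=O)(=O)Nc1ccc(-c2nc3ccccc3o2)cc1`, also stands at a limit of > 63000 nM in this assay. So compound 1 stands with the other two at the limit of > 63000 nM in this assay, at which 3 of the 3 values shown sit, and the numbers shown do not separate the three.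

Compound 4, `O=S(=O)(Nc1ccc2oc(-c3ccccc3)nc2c1)c1cccc(F)c1`, has not yet been measured. It differs from compound 1 by 3-fluorophenyl in place of 2-hydroxyphenyl on a sulfonyl sulfur. Among the measured compounds shown here, no measured step between two compounds is available to guide the size of such a change, and none of the three measured compounds gives a number rather than a limit. The expected step is a step that the limit leaves unreadable from compound 1 to compound 4, none beyond the scatter. Compound 4 is therefore expected at 80000 nM, with a range from 20000 nM to 300000 nM, and most likely it too will be reported only as a limit.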

Compound 4, half-maximal inhibitory concentration: > 63000 nM
Compound 4 gave a limit, no number (the forecaster's own chance of this, stated with the estimate: 80%); the middle value does not contradict the limit.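

Compound 1 and compound 4 both give only a limit in this assay, not a number, so no step can be read between them: the limit of > 63000 nM in this assay, at which 4 of the 4 values shown sit.

The compounds shown leave open how strongly any of them inhibits, and whether 3-fluorophenyl in place of 2-hydroxyphenyl changes inhibition at all.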